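Moving from a neopentyl chain to a chlorinated ring

The source may hold more compounds than are shown below. What is called first, only, known or untested is meant among the compounds shown, and "the series" means these compounds.

Readings so far in an ADME assay on Huh-7 cells (Homo sapiens) for cytotoxicity, with a stated time of 72 h (a lower number here means that less compound is tolerated, a higher number that more compound is tolerated), are these
Compound 1 `CCOc1cccc2c1S(=O)(=O)N=C2C1=C(O)[C@H](C(C)C)N(CCC(C)(C)C)C1=O` reads > 33000 nM (a limit)
Compound 2 `CCOc1cccc2c1S(=O)(=O)N=C2C1=C(O)[C@H](C(C)(C)C)N(CCC(C)(C)C)C1=O` reads > 33000 nM (a limit)
Compound 3 `CCOc1cccc2c1S(=O)(=O)N=C2C1=C(O)[C@H](C2CCCCC2)N(CCC(C)(C)C)C1=O` reads > 33000 nM (a limit)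

Compound 2 has no exact number in this assay to start from, only the limit > 33000 nM (a limit and not a measured number). The same holds across the series, as the limit of > 33000 nM in this assay, at which 3 of the 3 values shown sit, shows.

Compound 4 `CCOc1cccc2c1S(=O)(=O)N=C2C1=C(O)[C@H](C(C)(C)C)N(Cc2cccc(Cl)c2)C1=O` keeps the shared core of compound 2 and changes one side chain. It carries 3-chlorophenyl in place of neopentyl on a saturated chain carbon bound to an amide-type nitrogen in a ring, which also reads as 3,3-dimethylbutyl to 3-chlorobenzyl (3-chlorophenyl in place of neopentyl on a saturated chain carbon bound to an amide-type nitrogen in a ring).

Among the measured compounds shown here, none of the measured steps touches this chain. All three exchange the isopropyl, tert-butyl or cyclohexyl group instead, and none has a readable size: (a step that the two limits leave unreadable from compound 1 to compound 2), (a step that the two limits leave unreadable from compound 1 to compound 3) and (a step that the two limits leave unreadable from compound 2 to compound 3). For the measured compounds named here, they offer no size to carry over, and no compound measured so far has an aromatic ring in this chain, so the forecast is uncertain. No clear shift is expected, and the expected step is small (a number no higher from compound 2 to compound 4 (the limit leaves the size open)). The estimate for compound 4 is 33000 nM (expected range 15000 nM to 60000 nM).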

Compound 4, half-maximal cytotoxic concentration: > 33000 nM
Compound 4 was reported as a limit; the forecaster's own chance of this, stated with the estimate: 70%; the middle value sits exactly at the limit.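

No step can be read from compound 2 to compound 4 in this assay, because both readings are limits and not numbers, as is true across the series: the limit of > 33000 nM in this assay, at which 4 of the 4 values shown sit.

The compounds shown leave open the actual half-maximal cytotoxic concentration of each compound, and so whether 3-chlorobenzyl and 3,3-dimethylbutyl differ at all here.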